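From 1,3-benzothiazol-5-yl to 4-(1,3-thiazol-5-yl)phenyl

The compounds below may be only part of what the source reports. "The series", "measured", "known", "first", "only" and "open" are said of these compounds alone.

In a functional assay on MCF7 cells (Homo sapiens) for antiproliferative activity, read by CellTiter-Glo, with a stated time of 5 days (on this read-out higher numbers stand for weaker inhibition and lower numbers for stronger inhibition), compound 1 (`N#Cc1ccc(/C(=C(\c2ccc(/C=C/C(=O)O)cc2)c2ccc3scnc3c2)C2CCC2)c(Cl)c1`) gives 1.4 nM and compound 2 (`O=C(O)/C=C/c1ccc(/C(=C(\c2ccc(C(F)(F)F)cc2Cl)C2CCC2)c2ccc3scnc3c2)cc1`) gives 2.6 nM so the two cannot be told apart. Compound 3 (`N#Cc1ccc(/C(=C(\c2ccc(/C=C/C(=O)O)cc2)c2ccc(-c3cncs3)cc2)C2CCC2)c(Cl)c1`) carries the change 4-(1,3-thiazol-5-yl)phenyl in place of 1,3-benzothiazol-5-yl on a double-bonded chain carbon bound to an aromatic carbon and a double-bonded chain carbon on the core of compound 1. Among the measured compounds shown here, the one measured step, a 1.9-fold higher number from compound 1 to compound 2 (0.27 log units; within the scatter) with trifluoromethyl in place of cyano, concerns another group and offers little guidance here. An expected step of an 8.6-fold higher number from compound 1 to compound 3 (0.93 log units; beyond the scatter) is therefore only a loose estimate, towards weaker inhibition. In this assay the estimated value for compound 3 is 12 nM with the expected range running from 3 nM to 60 nM for now.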

Compound 3, half-maximal inhibitory concentration: 2.9 nM
Compound 3: middle estimate off by 4.1-fold (0.62 log units), on the high side; the whole stated range lies above it.
By their numbers in this assay, from the lowest: compounds 1, 2 and 3 (each within the scatter of the next, the first and the last beyond it).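

In this assay, replacing 1,3-benzothiazol-5-yl with 4-(1,3-thiazol-5-yl)phenyl gives a 2.1-fold higher number from compound 1 to compound 3 (0.32 log units; beyond the scatter), a modest step. This position, on a double-bonded chain carbon bound to an aromatic carbon and a double-bonded chain carbon, therefore accepts a linked pair of rings in place of a fused pair with only a small loss of inhibition. Nothing available accounts for the size of this step.

Still open, from the compounds shown here alone, is how the step would change with trifluoromethyl in place of cyano. It is also unknown whether a morpholine or a simple amine could replace the thiazole.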